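The source may hold more compounds than are shown below. What is called first, only, known or untested is meant among the compounds shown, and "the series" means these compounds.

Measured in a functional assay on KG-1 cells (Homo sapiens) for cytotoxicity, read by luminescence and CellTiter-Glo, with a stated time of 3 days; a higher number here means a weaker inhibitor, a lower number a stronger inhibitor:
- compound 1 `COc1ccc(O)c(C(=O)Nc2ccc(C#N)cc2)c1`: > 10000 nM
- compound 2 `N#Cc1ccc(NC(=O)c2ccc(Cl)cc2O)cc1`: 1920 nM

Compound 1 sits at the limit of > 10000 nM in this assay, at which 1 of the 2 values shown sits; this is a limit of the assay and not a number.

Compound 3 `N#Cc1ccc(NC(=O)c2cc(-c3cccnc3)ccc2O)cc1` differs from compound 1 as follows: pyridin-3-yl in place of methoxy on an aromatic carbon. The pyridin-3-yl stands in place of methoxy on an aromatic carbon, para to a hydroxy group.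

Going by the values given here, no measured step covers this change. The only anchor for an expectation is compound 2, which reads 1920 nM as a real number in this assay. A stronger result is expected, with an estimated size of an at least 3.3-fold lower number from compound 1 to compound 3 (0.52 log units; beyond the scatter). The estimate for compound 3 is 3000 nM, with an expected range of 700 nM to 10000 nM.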

Compound 3, half-maximal inhibitory concentration: 8330 nM
Compound 3: middle estimate off by 2.8-fold (0.44 log units), on the low side; the measured number falls inside the stated range.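

At this position, on an aromatic carbon para to a hydroxy group, pyridin-3-yl in place of methoxy yields a readable number in this assay: compound 3 gives 8330 nM. Compound 1 gives only a limit of the assay, not a number: the limit of > 10000 nM in this assay, at which 1 of the 3 values shown sits.

The step reads an at least 1.2-fold lower number from compound 1 to compound 3 (0.07 log units; that floor lies within the scatter), so a real gain from this change is not established.

As far as these compounds go, what a plain phenyl, an amine or a carboxylic acid would read on this carbon stays open. The contribution of the ring nitrogen of pyridin-3-yl therefore cannot be separated from that of the ring itself.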